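The compounds below may be only part of what the source reports. "The series", "measured", "known", "first", "only" and "open" are said of these compounds alone.

Measured so far in a functional assay on PC-3 cells (Homo sapiens) for inhibition, read by sulforhodamine B assay, with a stated time of 48 h, tested at 50 uM; a lower number here means less inhibition of growth, a higher number more inhibition of growth at the concentration tested:
Compound 1 `COc1ccccc1/C=C/C(=O)/C=C/c1ccc(OCc2cn(CCCOc3cc(=O)oc4ccccc34)nn2)c(OC)c1`: "not active" (no number reported)
Compound 2 `COc1cc(/C=C/C(=O)/C=C/c2cc(OC)c(OC)c(OC)c2)ccc1OCc1cn(CCOc2cc(=O)oc3ccccc23)nn1`: 22%

Within the data shown here, compound 2 holds the only number in this small set, as compound 1 was reported without one, so its standing cannot be judged against a second figure. Compound 3 `COc1cc(/C=C/C(=O)/C=C/c2ccco2)ccc1OCc1cn(CCOc2cc(=O)oc3ccccc23)nn1` has not yet been measured in this assay. It differs from compound 2 by furan-2-yl in place of 3,4,5-trimethoxyphenyl on a double-bonded chain carbon bound to a double-bonded chain carbon. Among the measured compounds shown here, no step between measured compounds is available to size this change, so the expectation rests on compound 2 alone, at 22%. The change is expected to stay within the usual scatter, leaning slightly towards less inhibition, with an estimated a number 4 percentage points lower from compound 2 to compound 3 (within the scatter). Compound 3 is estimated at 18%, with an expected range of 5% to 35%.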

Compound 3, percent growth inhibition at one concentration: 14%
Compound 3: the middle estimate sits 4 percentage points above what was measured; the range from low to high includes it.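

In this assay, furan-2-yl in place of 3,4,5-trimethoxyphenyl on a double-bonded chain carbon bound to a double-bonded chain carbon gives a number 8 percentage points lower from compound 2 to compound 3 (within the scatter). This position therefore accepts a group of 5 heavy atoms in place of one with more heavy atoms, and a five-membered aromatic ring with 1 hetero atom in place of a six-membered aromatic ring of carbon only, with the two readings remaining within the usual scatter. No other data shown bear on this result.

Compound 1 differs from compound 2 and compound 3 in more than one place, so it cannot size any single change. The compounds shown leave open whether pyridin-2-yl, or a phenyl ring carrying a carboxylic acid, at this position would give a reading beyond the scatter.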